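Selenocyanate carbamates and diselenides: cytotoxicity in a breast cell line

The compounds below may be only part of what the source reports. "The series", "measured", "known", "first", "only" and "open" are said of these compounds alone.

Measured compounds:
Compound 1 `CCCOC(=O)Nc1ccc([Se]C#N)cc1`: 3700 nM
Compound 2 `CCOC(=O)Nc1ccc([Se][Se]c2ccc(NC(=O)OCC)cc2)cc1`: 5700 nM
Compound 3 `O=C(Nc1ccc([Se][Se]c2ccc(NC(=O)Oc3ccccc3)cc2)cc1)Oc1ccccc1`: 4500 nM

Three carbamates were tested in an ADME assay on 184B5 cells (Homo sapiens) for cytotoxicity, read by MTT assay, with a stated time of 72 h; a higher number here means a weaker inhibitor of growth, a lower number a stronger inhibitor of growth. Compound 1 carries a selenocyanate on its core and gives 3700 nM in this assay. Compound 2 and compound 3 are diselenides joining two such carbamate-bearing cores; compound 2 gives 5700 nM and compound 3 gives 4500 nM. Compound 1 has the lowest of the three numbers, yet both compound 3 and compound 2 fall within the usual scatter of it, so no difference among the three can be claimed.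

Compound 4 `N#C[Se]c1ccc(NC(=O)Oc2ccccc2)cc1` has not yet been measured. It differs from compound 1 in one place: phenyl in place of propyl on an oxygen next to a carbonyl group. The same exchange of ethyl for phenyl on the carbamate oxygen separates compound 2 from compound 3, where the two values lie within the scatter of each other. No step beyond the scatter is therefore expected in this assay, in either direction. Compound 4 is expected to give about 3500 nM, with a range from 1500 nM to 8000 nM. The step from compound 1 that this estimate means, a 1.1-fold lower number from compound 1 to compound 4 (0.02 log units; within the scatter), is expected to stay within the scatter.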

Compound 4, concentration for 50% growth inhibition: 400 nM
For compound 4 the middle estimate is 8.8-fold (0.94 log units) above the measured one; the measured number lies below the stated range.
By their numbers in this assay, from the lowest: compound 4; then compounds 1, 3 and 2 (each within the scatter of the next).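

In this assay, phenyl in place of propyl on an oxygen next to a carbonyl group gives a 9.3-fold lower number from compound 1 to compound 4 (0.97 log units; beyond the scatter), which shows that with a selenocyanate on the core, the group at this place can move the number well beyond the scatter. The earlier compounds gave no sign of this: among the diselenides, compound 2 gives 5700 nM and compound 3 gives 4500 nM, two values within the scatter of each other, although ethyl and phenyl are exchanged at the same place, so among the compounds shown a step of this kind appears only in the selenocyanate pair. No measurement at hand bears on why the exchange counts in one pair and not in the other.

From the compounds shown here alone, whether a cyclohexyl group, a benzyl group or a longer chain on that oxygen would give a number closer to that of compound 1 or to that of compound 4 remains open, and with it whether the aromatic ring itself is what matters. Going by these compounds, it also remains open whether the same step would appear in any other cell line.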